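A few compounds are considered here, and "the series" means these few. Any claim that something is new, unique, unknown or untested is made for them only; others in the source may bear on it.

Compound 1 `COCc1cc(Br)c(O)c(O)c1Br` is measured in a functional assay on DLD-1 cells (Homo sapiens) for cytotoxicity, read by MTT assay, with a stated time of 96 h (a higher number here means a weaker inhibitor, a lower number a stronger inhibitor), and gives 7270 nM. Compound 2 `CCOCc1cc(O)c(O)c(Br)c1Br` gives 13500 nM in this assay, and compound 3 `CCCOCc1cc(O)c(O)c(Br)c1Br` gives 12400 nM. The difference between the core of compound 1 and the core of compound 2 is not broken down here. Between compound 2 and compound 3 the change is methyl in place of hydrogen on a saturated chain carbon, two bonds along the chain from an oxygen on a saturated carbon, and it made a 1.1-fold lower number from compound 2 to compound 3 (0.04 log units; within the scatter). Compound 4 `CCOCc1cc(Br)c(O)c(O)c1Br` is not yet measured; it differs from compound 1 by methyl in place of hydrogen on a saturated chain carbon bound to an oxygen on a saturated carbon, the same kind of change, though here the place is a saturated chain carbon bound to an oxygen on a saturated carbon rather than two bonds along the chain from it. Because a 1.1-fold lower number from compound 2 to compound 3 (0.04 log units; within the scatter) stayed within the scatter, compound 4 is expected to show a step of a 1.0-fold higher number from compound 1 to compound 4 (0.01 log units; within the scatter). Compound 4 is therefore estimated at 7500 nM, between 4000 nM and 14000 nM.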

Compound 4, half-maximal inhibitory concentration: 7150 nM
For compound 4 the middle estimate is 1.0-fold (0.02 log units) above the measured one; the measured number falls inside the stated range.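

In this assay, methyl in place of hydrogen on a saturated chain carbon bound to an oxygen on a saturated carbon, which turns methoxymethyl into ethoxymethyl, gave a 1.0-fold lower number from compound 1 to compound 4 (0.01 log units; within the scatter). Set beside the earlier step, the change reads alike on the two cores: the same change on two cores in this assay, a 1.1-fold lower number (0.04 log units; within the scatter) from compound 2 to compound 3 and a 1.0-fold lower number (0.01 log units; within the scatter) from compound 1 to compound 4, 1.1-fold (0.03 log units) apart, within the scatter of two such steps

This shows that the change made no readable difference in either of these two cases, though at different places on the chain, but it does not show that the same would hold on any other core, or that the chain plays no part in the activity. Going by these compounds, whether a longer chain, a branched chain, or an amine or carboxylic acid at the end of the chain would shift the number remains open. So does whether the flat result extends to any other cell line.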